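The source may report more compounds than this note shows. Statements on the series, on what has been measured and on what is new or still open speak of the compounds shown alone.

Measured compounds in a functional assay on CHO cells for agonist activity at Free fatty acid receptor 1 (Homo sapiens), read by FLIPR and calcium flux, with a stated time of 90 s, tested at 100 nM; on this read-out higher numbers stand for a stronger effect at the one concentration tested and lower numbers for a weaker effect:

Compound 1 `Cc1cccc(C)c1-c1cccc(COc2ccc3c(c2)OCC3CC(=O)O)c1`: in this assay compound 1 gives 62.6%

Compound 2 `Cc1ccc(C)n1-c1cccc(COc2ccc3c(c2)OCC3CC(=O)O)c1`: in this assay compound 2 gives 59.9%

Compound 2 holds the lowest of the two numbers in this assay, but its nearest neighbour is compound 1 and the gap, a number 2.7 percentage points lower from compound 1 to compound 2 (within the scatter), lies within the scatter, so the two cannot be ordered. Within the data shown here, that single step, 2,5-dimethyl-1H-pyrrol-1-yl in place of 2,6-dimethylphenyl on an aromatic carbon, is the only measured change in the set.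

Compound 3 `COc1ccc(COc2ccc3c(c2)OCC3CC(=O)O)cc1-n1c(C)ccc1C` differs from compound 2 by methoxy in place of hydrogen on an aromatic carbon; the new group sits on an aromatic carbon of a six-membered aromatic ring of carbon only, ortho to the 2,5-dimethyl-1H-pyrrol-1-yl group and para to a large group. Among the measured compounds shown here, no measured step touches this position or this kind of change, so the step from compound 1 to compound 2 bears on it only indirectly, showing that one alteration on the same part of the core left the number inside the scatter. No step beyond the scatter is therefore expected; the expected step is a number 1.9 percentage points lower from compound 2 to compound 3 (within the scatter). The estimate for compound 3 in this assay is 58%, with a range from 38% to 76%.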

Compound 3, a percentage reported as activity, at one concentration (the size of the read-out at that concentration, not a potency): 63.8%
Estimate against measurement, compound 3: 5.8 percentage points below; measured number inside the range.
By their numbers in this assay, from the lowest: compounds 2, 1 and 3 (each within the scatter of the next).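

In this assay, methoxy in place of hydrogen on an aromatic carbon, ortho to the 2,5-dimethyl-1H-pyrrol-1-yl group and para to a large group, gives a number 3.9 percentage points higher from compound 2 to compound 3 (within the scatter). Among these compounds, this is the first measured change at this position of the series, and the earlier step concerned only the exchange of 2,6-dimethylphenyl for 2,5-dimethyl-1H-pyrrol-1-yl; at the one concentration tested, the methoxy group is tolerated here with no readable change in the size of the effect, and whether the two compounds would differ at any other concentration remains unresolved. No data at hand bear on the reason for this outcome.

Open, as far as these compounds go, is whether a larger or differently built group at this position, such as an amine, a carboxylic acid or a longer alkoxy chain, would also stay within the scatter. Also open, from the compounds shown here alone, is whether methoxy at the matching position would give the same result on the 2,6-dimethylphenyl group of compound 1, and whether a full concentration series would separate these compounds.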